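This account rests on a few compounds, and the source may have more. Where it says the series, first, only, none or still open, it means among the compounds named here.

Compound 1 `COc1cc(C(=O)N/N=C/c2cccc(F)c2)cc(OC)c1OC`: 64.1%
Compound 2 `COc1ccc(OC)c(C2OC(c3cc(OC)c(OC)c(OC)c3)=NN2C(C)=O)c1`: 43.2%

In a functional assay on PC-3 cells (Homo sapiens) for antiproliferative activity, read by MTT assay, tested at 5 uM (a lower number here means a weaker effect, a higher number a stronger effect of the compound at the concentration tested), compound 2 gives the lower of the two numbers; compound 1 lies above it by a gap beyond the usual scatter. Compound 3 `COc1cc(C2=NN(C(C)=O)C(c3ccc(F)c(F)c3)O2)cc(OC)c1OC` is reached from compound 2 by one change: 3,4-difluorophenyl in place of 2,5-dimethoxyphenyl on a saturated ring carbon. Going by the values given here, no pair of measured compounds shows this change on its own, so its effect is unknown here. A modest rise is expected, with no certainty that it would exceed the scatter, so the estimated step is a number 6.8 percentage points higher from compound 2 to compound 3 (within the scatter). Compound 3 is therefore expected to give about 50%, within a range from 30% to 70%.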

Compound 3, a percentage reported as inhibition, at one concentration (the size of the read-out at that concentration, not a potency): 46.9%
Compound 3: the middle estimate sits 3.1 percentage points above what was measured; the measured number falls inside the stated range.
By their numbers in this assay, from the lowest: compounds 2 and 3 (each within the scatter of the next); then compound 1.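

In this assay, putting 3,4-difluorophenyl in place of 2,5-dimethoxyphenyl on the saturated ring carbon gives a number 3.7 percentage points higher from compound 2 to compound 3 (within the scatter). This position therefore takes either aromatic ring without a difference that can be told from the scatter, even though the group that leaves has 2 hydrogen-bond acceptors and the group that enters has 0. No measurement on hand explains why the two groups read alike. As far as these compounds go, whether an amine or a carboxylic acid on the ring at this carbon would shift the number remains open.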